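The source may hold more compounds than are shown below. What is called first, only, known or untested is meant among the compounds shown, and "the series" means these compounds.

Among the compounds with values here, in a functional assay on MCF7 cells (Homo sapiens) for antiproliferative activity, read by MTT assay, with a stated time of 24 h (on this read-out lower numbers stand for stronger inhibition and higher numbers for weaker inhibition), compound 2 `O=S(=O)(c1ccc(Cl)cc1)n1c(-c2cn(-c3ccccc3)nc2-c2ccc(C(F)(F)F)cc2)nc2ccccc21` gives 4320 nM and stands highest of the two numbers so far, with compound 1 `Cc1ccc(C)c(S(=O)(=O)n2c(-c3cn(-c4ccccc4)nc3-c3ccc(C(F)(F)F)cc3)nc3ccccc32)c1` at 170 nM on the same measure. Compound 3 `O=S(=O)(c1ccc(C(F)(F)F)cc1)n1c(-c2cn(-c3ccccc3)nc2-c2ccc(C(F)(F)F)cc2)nc2ccccc21` carries trifluoromethyl in place of chloro on an aromatic carbon para to a large group. Within the data shown here, the one measured step at this sulfonyl sulfur is the large 25-fold higher number from compound 1 to compound 2 (1.41 log units; beyond the scatter) but it swapped 2,5-dimethylphenyl, not this para group, so no step beyond the scatter is expected in this assay in either direction. The expected change is a 1.2-fold lower number from compound 2 to compound 3 (0.09 log units; within the scatter) at the middle estimate. For compound 3 the estimate is 3500 nM with a range from 900 nM to 12000 nM expected.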

Compound 3, half-maximal inhibitory concentration: 1240 nM
Estimate against measurement, compound 3: 2.8-fold (0.45 log units) above; the measured number falls inside the stated range.
By their numbers in this assay, from the lowest: compound 1; then compound 3; then compound 2.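

Replacing 4-chlorophenyl with 4-(trifluoromethyl)phenyl on the sulfonyl sulfur gives in this assay a 3.5-fold lower number from compound 2 to compound 3 (0.54 log units; beyond the scatter), so the group at this one place moves the number beyond the scatter, which the earlier step, with its change of the whole aryl group, could not show. The 2,5-dimethylphenyl group still holds the lowest number, with a 7.3-fold higher number from compound 1 to compound 3 (0.86 log units; beyond the scatter). Nothing at hand gives a cause for either step. Still open, on these data alone, is how a nitrile or an amine would read at this place on the phenyl ring, and whether a single methyl group would reach the number of compound 1 170 nM.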